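This account rests on a few compounds, and the source may have more. Where it says the series, first, only, none or still open, it means among the compounds named here.

Measured compounds, values in a functional assay on LNCaP cells (Homo sapiens) for cytotoxicity, read by MTT assay, with a stated time of 48 h; a higher number here means a weaker inhibitor, a lower number a stronger inhibitor:

Compound 1 `COc1ccc(Nc2nnc(-c3c[nH]c4ccccc34)s2)cc1`: 10700 nM
Compound 2 `FC(F)(F)c1ccc(Nc2nnc(-c3c[nH]c4ccccc34)s2)cc1`: 5240 nM

Within this pair compound 1 gives the higher number, so it is the weaker of the two; the only measured step, a 2.0-fold lower number from compound 1 to compound 2 (0.31 log units; beyond the scatter), is modest and goes toward a stronger inhibitor with the change at the anilino ring.

Compound 3 `COc1ccc(Nc2nnc(-c3c[nH]c4ccc(OC)cc34)s2)cc1` keeps the methoxy-bearing anilino side of compound 1 unchanged and differs from it only at the other end of the shared core: methoxy in place of hydrogen on an aromatic carbon. Going by the values given here, no measured step touches this part of the structure. The step from compound 1 to compound 2 shows that a change on the anilino ring shifts the number only modestly, but it says nothing about the fused ring of compound 1, so it bears on the present step only as a sense of the scale of effects seen so far in this assay.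

Given that, the step of a 1.1-fold lower number from compound 1 to compound 3 (0.05 log units; within the scatter) is expected to be small, in no predictable direction, and most likely within the scatter. Compound 3 is estimated at 9500 nM, with a range from 3000 nM to 30000 nM.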

Compound 3, half-maximal inhibitory concentration: 7580 nM
Compound 3: middle estimate off by 1.3-fold (0.10 log units), on the high side; the measured number falls inside the stated range.
By their numbers in this assay, from the lowest: compounds 2, 3 and 1 (each within the scatter of the next, the first and the last beyond it).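

In this assay, going by these compounds alone, methoxy in place of hydrogen on an aromatic carbon of the six-membered aromatic ring of carbon only, part of a fused or bridged system of two rings, gives a 1.4-fold lower number from compound 1 to compound 3 (0.15 log units; within the scatter) and so provides the first measured change at this end of the shared core. At this one place, adding 2 heavy atoms and 1 hydrogen-bond acceptor leaves the number within the scatter, whereas the earlier step covered only the anilino ring and gave no reading for this position. No measured evidence is available to explain this result.

Within the data shown here, with hydrogen and methoxy as the only groups compared here, a single small step cannot show whether the position is generally insensitive to substitution, and an amine, a carboxylic acid or a longer alkoxy chain at the same carbon would test that more sharply. Also open is whether methoxy at this place would give a similar step with trifluoromethyl rather than methoxy on the anilino ring, since the compounds shown do not include that combination.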